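The source may hold more compounds than are shown below. What is called first, only, known or untested is meant among the compounds shown, and "the series" means these compounds.

In a functional assay on the whole organism (strain Swiss) with Mus musculus as the target, in the maximal electroshock model, with a stated time of 2 h, at a dose of 100 mg/kg by the intraperitoneal route (on this read-out higher numbers stand for a stronger effect at the one dose given and lower numbers for a weaker effect), the measured compounds stand as follows:

compound 1 `CC(C(=O)N1CCN(c2ccccc2)CC1)N1C(=O)CCC1=O` gives 0%
compound 2 `CC(C(=O)N1CCN(c2ccccc2F)CC1)N1C(=O)CCC1=O` gives 0%
compound 3 `CC(C(=O)N1CCN(c2ccc(F)cc2)CC1)N1C(=O)CCC1=O` gives 0%

Compound 2 is level with compounds 1 and 3 on this read-out. The steps between the measured compounds are all small: no change at the digits printed from compound 1 to compound 2 (within the scatter), no change at the digits printed from compound 1 to compound 3 (within the scatter), and no change at the digits printed from compound 2 to compound 3 (within the scatter). Within the data shown here, every one of them lies within the scatter, so the series so far shows no movement in this assay at all.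

Compound 4 `CC(C(=O)N1CCN(c2ccccc2C(F)(F)F)CC1)N1C(=O)CCC1=O` is the next member. It differs from compound 2 by trifluoromethyl in place of fluoro on an aromatic carbon. Among the measured compounds shown here, the steps that bear on this change are those that altered the same aromatic ring of compound 1 and compound 2, and each was within the scatter. For the measured compounds named here, no measured step introduces a trifluoromethyl group, so the expectation rests only on the flat picture given by compounds 1, 2 and 3. From that picture the step of no change at the digits printed from compound 2 to compound 4 (within the scatter) is expected to stay within the scatter, with no direction to it. Compound 4 is therefore estimated at 0% in this assay, with a range from 0% to 15%.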

Compound 4, a percentage reported as activity, at one dose (the size of the read-out at that dose, not a potency): 0%
Compound 4: the middle estimate sits on the measured number at the digits printed, within the range that was stated.
By their numbers in this assay, from the lowest: compounds 1, 2, 3 and 4 (each within the scatter of the next).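

Trifluoromethyl on an aromatic carbon, ortho to a large group, brings more heavy atoms to this place than fluoro, yet in this assay the read-out shows no change at the digits printed from compound 2 to compound 4 (within the scatter) and, against the unsubstituted ring, no change at the digits printed from compound 1 to compound 4 (within the scatter). The flat picture at this position therefore holds for a group larger by heavy-atom count, not only for the single-atom swap to fluoro. No data on hand speak to why this read-out stays flat.

With all the compounds level, the series does not yet show whether any change to the shared core can move this read-out at this dose. Open, from the compounds shown here alone, is whether an amine or a carboxylic acid on the same aromatic carbon, or a longer chain elsewhere on the core, would depart from this level.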